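Amide nitrogen substituents on the shared core

The source may hold more compounds than are shown below. What is called first, only, known or untested is meant among the compounds shown, and "the series" means these compounds.

Measured so far:
compound 1 `CCNC(=O)C1=CC(C)(C)Oc2ccc([N+](=O)[O-])cc21`: 80.5%
compound 2 `CC(C)NC(=O)C1=CC(C)(C)Oc2ccc([N+](=O)[O-])cc21`: 77.6%

In a functional assay on the whole organism (muscle tissue) with Rattus norvegicus as the target (on this read-out higher numbers stand for larger maximal responses and lower numbers for smaller maximal responses), compound 1 gives 80.5% and compound 2 gives 77.6%. Going by the values given here, the single step among them is a number 2.9 percentage points lower from compound 1 to compound 2 (within the scatter), so compound 2 stands alongside compound 1, the two not separated beyond the scatter.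

Compound 3 `CC1(C)C=C(C(=O)NCC2CC2)c2cc([N+](=O)[O-])ccc2O1` differs from compound 2 by cyclopropylmethyl in place of isopropyl on an amide-type nitrogen. Among the compounds with values here, only the step of a number 2.9 percentage points lower from compound 1 to compound 2 (within the scatter) bears on this, as it too alters the substituent on the amide-type nitrogen, and it stayed within the scatter. No step beyond the scatter is therefore expected in this assay: the expected step is a number 0.4 percentage points higher from compound 2 to compound 3 (within the scatter). Compound 3 is estimated at 78%, within 66% to 88%.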

Compound 3, intrinsic activity: the largest response reached, in percent of the reference agonist's: 89.3%
Compound 3: middle estimate off by 11.3 percentage points, on the low side, outside the stated range (above it).
By their numbers in this assay, from the lowest: compounds 2, 1 and 3 (each within the scatter of the next, the first and the last beyond it).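

In this assay the substituent on the amide-type nitrogen can shift the maximal response: the series shows a number 11.7 percentage points higher from compound 2 to compound 3 (beyond the scatter) with cyclopropylmethyl in place of isopropyl, its first step beyond the scatter. Compound 1 stays unseparated from compound 3, with a number 8.8 percentage points higher from compound 1 to compound 3 (within the scatter) for cyclopropyl in place of methyl on the chain carbon. No evidence on the origin of the larger step is available. Going by these compounds, whether the three-membered ring itself matters remains open, since a straight butyl chain or a cyclobutylmethyl group on the same nitrogen would be needed to separate ring from chain length.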